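The source may hold more compounds than are shown below. What is called first, only, known or untested is meant among the compounds shown, and "the series" means these compounds.

Working notes on the urea series sharing one core. In a functional assay on NCI-H460 cells (Homo sapiens) for cytotoxicity, read by MTT assay, with a stated time of 72 h (on this read-out higher numbers stand for weaker inhibition and lower numbers for stronger inhibition), compound 1 `CN(C)CCNc1nc(-c2ccc(NC(=O)Nc3ccccc3F)cc2)nc2ccsc12` gives 410 nM, and compound 2 `CN(C)CCNc1nc(-c2ccc(NC(=O)Nc3ccccc3Cl)cc2)nc2ccsc12` gives 230 nM; the step of a 1.8-fold lower number from compound 1 to compound 2 (0.25 log units; within the scatter) does not separate them. Compound 3 `CN(C)CCNc1nc(-c2ccc(NC(=O)Nc3ccc(Cl)cc3Cl)cc2)nc2ccsc12` gives 1650 nM in this assay and stands highest of the three numbers, the steps to it reading a 4.0-fold higher number from compound 1 to compound 3 (0.60 log units; beyond the scatter) and a 7.2-fold higher number from compound 2 to compound 3 (0.86 log units; beyond the scatter).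

Compound 4 `Cc1ccc(NC(=O)Nc2ccc(-c3nc(NCCN(C)C)c4sccc4n3)cc2)cc1` awaits measurement in this assay. The change from compound 3 is 4-methylphenyl in place of 2,4-dichlorophenyl on an amide-type nitrogen. Within the data shown here, no measured step reaches a 4-methylphenyl urea, so the bearing is indirect. Two steps inform it: a 7.2-fold higher number from compound 2 to compound 3 (0.86 log units; beyond the scatter) shows the added chloro raising the number, and a 4.0-fold higher number from compound 1 to compound 3 (0.60 log units; beyond the scatter) shows the dichlorophenyl above the fluorophenyl. Removing both chlorines is therefore expected to bring the number back down toward the range of compound 1 and compound 2, with the methyl itself untested. The expected step is a 4.7-fold lower number from compound 3 to compound 4 (0.67 log units; beyond the scatter). For compound 4 the estimate in this assay is 350 nM, with a range of 130 nM to 1000 nM.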

Compound 4, half-maximal inhibitory concentration: 1880 nM
For compound 4 the middle estimate is 5.4-fold (0.73 log units) below the measured one; the whole stated range lies below it.
By their numbers in this assay, from the lowest: compounds 2 and 1 (each within the scatter of the next); then compounds 3 and 4 (each within the scatter of the next).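

In this assay, the step of a 1.1-fold higher number from compound 3 to compound 4 (0.06 log units; within the scatter) shows that taking out both chlorines and putting in the 4-methylphenyl group on the amide-type nitrogen leaves the number unmoved, so chlorine is not needed for the higher numbers in this series. The steps of an 8.2-fold higher number from compound 2 to compound 4 (0.91 log units; beyond the scatter) and a 4.6-fold higher number from compound 1 to compound 4 (0.66 log units; beyond the scatter) place the 4-methylphenyl urea clearly apart from the 2-chlorophenyl and 2-fluorophenyl ureas, and the four compounds now fall into two groups: those two at the lower numbers, and the 2,4-dichlorophenyl and 4-methylphenyl ureas at the higher. Nothing available explains this grouping.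

Still open, from the compounds shown here alone, is how an unsubstituted phenyl urea would stand against these groups. A 2-methylphenyl or 4-chlorophenyl urea would show whether the grouping follows the place of the group on the ring or the group itself.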